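Formamide series: from compound 3 to compound 4

This account rests on a few compounds, and the source may have more. Where it says the series, first, only, none or still open, it means among the compounds named here.

The series shares one core and differs only in the group on the aromatic carbon of the five-membered ring. Compound 1 `Cc1nc2c(OCc3ccccc3)cccn2c1NC=O` carries the formamide; in a functional assay on the whole organism with Rattus norvegicus as the target, at a dose of 40 mg/kg by the intraperitoneal route (a higher number here means more inhibition at the dose given (going by the name of the read-out), a lower number less inhibition), compound 1 gives 49%. Compound 2 `COC(=O)Nc1c(C)nc2c(OCc3ccccc3)cccn12` carries the methyl carbamate; in this assay compound 2 gives 0%. Compound 3 `Cc1nc2c(OCc3ccccc3)cccn2c1NC(C)C` carries the isopropylamino group; in this assay compound 3 gives 18%. On these numbers compound 3 stands second of the three, beyond the scatter from both others: a number 31 percentage points lower from compound 1 to compound 3 (beyond the scatter) and a number 18 percentage points higher from compound 2 to compound 3 (beyond the scatter).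

Compound 4 `COc1c(C)nc2c(OCc3ccccc3)cccn12` is the next step: methoxy in place of isopropylamino on an aromatic carbon. Every measured step touches the same place, and each move away from the formamide lowered the read-out: a number 49 percentage points lower from compound 1 to compound 2 (beyond the scatter) and a number 31 percentage points lower from compound 1 to compound 3 (beyond the scatter). The only rise, a number 18 percentage points higher from compound 2 to compound 3 (beyond the scatter), came from the lowest point. Among the compounds with values here, no measured step removes the nitrogen from this place, so the size of the step is open; the three points suggest a fall rather than a gain. The expected step is a number 8 percentage points lower from compound 3 to compound 4 (within the scatter), downward, of a size that may stay within the scatter. For compound 4 the estimate in this assay is 10%, with a range from 0% to 30%.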

Compound 4, a percentage reported as inhibition, in the whole organism at one dose (the size of the read-out at that dose, not a potency): 49%
Estimate against measurement, compound 4: 39 percentage points below; measured number outside the range, above it.
By their numbers in this assay, from the lowest: compound 2; then compound 3; then compounds 1 and 4 (each within the scatter of the next).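

In this assay a nitrogen on this aromatic carbon proves not to be needed: methoxy gives a number 31 percentage points higher from compound 3 to compound 4 (beyond the scatter) and, against the methyl carbamate, a number 49 percentage points higher from compound 2 to compound 4 (beyond the scatter) while all three earlier compounds kept a nitrogen at this place. The formamide also loses its apparent special standing, since replacing formylamino with methoxy gives no change at the digits printed from compound 1 to compound 4 (within the scatter) and so two quite different groups sit level here. Methoxy enters with 0 hydrogen-bond donors where isopropylamino has 1, so a donor on this atom is not required for the read-out of compound 4 at 49% in this assay at the single dose given.

From the compounds shown here alone, whether an ethoxy group, a hydroxyl or a primary amine on this carbon would hold the read-out remains open, as does how the series ranks at other doses. Nothing measured here explains why methoxy and formylamino sit level while isopropylamino and the methyl carbamate fall lower.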